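Amide aryl variation on the shared core

The compounds below may be only part of what the source reports. "The series", "measured", "known", "first", "only" and "open" are said of these compounds alone.

Measured so far:
compound 1 `O=C(Nc1cccc(-c2oc3cc(-c4ccc(F)cc4)ccc3c(=O)c2O)c1)c1ccccc1F` — 10800 nM in a functional assay on HCC1937 cells (Homo sapiens) for antiproliferative activity, read by CCK-8 assay, with a stated time of 72 h; a higher number here means a weaker inhibitor, a lower number a stronger inhibitor
compound 2 `CCc1ccc(C(=O)Nc2cccc(-c3oc4cc(-c5ccc(F)cc5)ccc4c(=O)c3O)c2)cc1` — 13200 nM in this assay

Compound 2 stands at the higher of the two numbers measured in this assay, but its nearest neighbour is compound 1, and the step of a 1.2-fold higher number from compound 1 to compound 2 (0.09 log units; within the scatter) lies within the scatter, so the two compounds cannot be ordered on these data.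

Compound 3 `Cc1cc(C(=O)Nc2cccc(-c3oc4cc(-c5ccc(F)cc5)ccc4c(=O)c3O)c2)ccc1F` is not yet measured. It differs from compound 2 in one place: 4-fluoro-3-methylphenyl in place of 4-ethylphenyl on a carbonyl carbon. Going by the values given here, the only measured step that bears on this position is the one from compound 1 to compound 2, a 1.2-fold higher number from compound 1 to compound 2 (0.09 log units; within the scatter), where one aryl group on the carbonyl carbon replaced another without moving the number beyond the scatter. Among the compounds with values here, nothing else among the measured compounds touches this position, so the one exchange of aryl groups already seen is the whole basis for an expectation.

On that basis no step beyond the scatter is expected for compound 3 in this assay, and the expected step is a 1.1-fold lower number from compound 2 to compound 3 (0.04 log units; within the scatter). The estimate for compound 3 in this assay is 12000 nM, with a range from 5000 nM to 30000 nM.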

Compound 3, half-maximal inhibitory concentration: 5420 nM
Compound 3: middle estimate off by 2.2-fold (0.35 log units), on the high side, within the range that was stated.
By their numbers in this assay, from the lowest: compounds 3, 1 and 2 (each within the scatter of the next, the first and the last beyond it).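

In this assay the aryl group on the carbonyl carbon now gives a step beyond the scatter, as a 2.4-fold lower number from compound 2 to compound 3 (0.39 log units; beyond the scatter) comes with 4-fluoro-3-methylphenyl in place of 4-ethylphenyl, so the number at this position can move, if only modestly. The exchange of 2-fluorophenyl for 4-fluoro-3-methylphenyl gives a 2.0-fold lower number from compound 1 to compound 3 (0.30 log units; within the scatter) and stays inside the scatter, so compound 3 is separated from compound 2 only, and the three aryl groups do not fall into a full order. Nothing available explains why these aryl groups differ in this assay.

Open, from the compounds shown here alone, is whether this position can carry a larger step with a different group, such as a phenyl ring bearing a nitrile or trifluoromethyl, a pyridine ring, or a non-aromatic group such as cyclohexyl or a short chain ending in an amine. Also open, going by these compounds, is whether the separation of compound 3 from compound 2 holds with the fluorophenyl group on the shared core replaced, or in cell lines other than the one in this assay alone.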